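A few compounds are considered here, and "the series" means these few. Any claim that something is new, unique, unknown or untested is made for them only; others in the source may bear on it.

Working notes on the series: the compounds share one core and differ in the group on a saturated ring carbon. In an ADME assay on Vero cells (Chlorocebus sabaeus) for cytotoxicity, read by MTT assay, with a stated time of 48 h (on this read-out higher numbers stand for weaker inhibition and lower numbers for stronger inhibition), compound 1 `CC(C)S(=O)(=O)OC1CCC(CN2CCN(c3cc(=O)c4cc(C(F)(F)F)cc([N+](=O)[O-])c4s3)CC2)CC1` gives > 64 ug/mL, which is a limit of the assay and not a number. Compound 2 `CS(=O)(=O)NC1CCC(CN2CCN(c3cc(=O)c4cc(C(F)(F)F)cc([N+](=O)[O-])c4s3)CC2)CC1` gives 48.5 ug/mL. Compound 3 `O=C(NC1CCC(CN2CCN(c3cc(=O)c4cc(C(F)(F)F)cc([N+](=O)[O-])c4s3)CC2)CC1)c1ccccc1` gives 44.3 ug/mL. Among the compounds with values here, compound 3 and compound 2 are the only two with numbers, and they lie within the scatter of each other, as a 1.1-fold lower number from compound 2 to compound 3 (0.04 log units; within the scatter) shows.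

Compound 4 `O=C(OC1CCC(CN2CCN(c3cc(=O)c4cc(C(F)(F)F)cc([N+](=O)[O-])c4s3)CC2)CC1)c1cccc(F)c1` is still unmeasured. Relative to compound 3 it carries ((3-fluorophenyl)carbonyl)oxy in place of benzamido on a saturated ring carbon.

The nearest evidence is the exchange of (isopropylsulfonyl)oxy for an amide-type group, with an at least 1.4-fold lower number from compound 1 to compound 3 (0.15 log units; that floor lies within the scatter) and an at least 1.3-fold lower number from compound 1 to compound 2 (0.12 log units; that floor lies within the scatter). Both steps rest on (the limit of > 64 ug/mL in this assay, at which 1 of the 3 values shown sits), so they give a floor and not a size. Read in reverse, an at least 1.4-fold lower number from compound 1 to compound 3 (0.15 log units; that floor lies within the scatter) leans toward a higher number for an oxy group in place of benzamido, but no step beyond the scatter is expected in this assay. The estimated step is a 1.2-fold higher number from compound 3 to compound 4 (0.09 log units; within the scatter). A limit reading is also possible. For compound 4 the estimated value is 55 ug/mL, with an expected range from 30 ug/mL to 95 ug/mL.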

Compound 4, half-maximal inhibitory concentration: > 64 ug/mL
Compound 4 ended at the assay's limit (the forecaster's own chance of this, stated with the estimate: 35%); middle value at least 1.1-fold (0.06 log units) away from the limit.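

On this saturated ring carbon, in this assay, replacing benzamido or methanesulfonamido with ((3-fluorophenyl)carbonyl)oxy gives an at least 1.4-fold higher number from compound 3 to compound 4 (0.15 log units; that floor lies within the scatter) and an at least 1.3-fold higher number from compound 2 to compound 4 (0.12 log units; that floor lies within the scatter); both are floors, so neither shows a change beyond the scatter. What is new is that a second group joined through oxygen, this one carrying a six-membered aromatic ring as benzamido does, also reads at a limit, so compound 1 and compound 4 sit at the limit while compound 2 and compound 3, joined through nitrogen, give numbers, and no compound shown goes against this split. The step between compound 1 and compound 4 cannot be read: the limit of > 64 ug/mL in this assay, at which 2 of the 4 values shown sit.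

Going by these compounds, how far the true values of compound 1 and compound 4 lie past the limit remains open, and with it the real size of exchanging the nitrogen link for the oxygen link. Also open, on these data alone, are how an amine or a carboxylic acid on this ring carbon would read and whether the fluorine in compound 4 has any part in its result.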